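A few compounds are considered here, and "the series" means these few. Any claim that something is new, unique, unknown or untested is made for them only; others in the source may bear on it.

Working notes on the series. Within the data shown here, in an ADME assay on microsomes from liver (Homo sapiens) for metabolic stability (a lower number here means slower removal, a higher number faster removal of the compound), compound 2 `Cc1cccc([C@H](C)NC(=O)Cn2nnc3ccccc3c2=O)c1` gives 11 mL/min/kg, the only true number so far.

Compound 1 `CC(NC(=O)Cn1nnc2ccccc2c1=O)c1ccc(Cl)cc1` reads < 9.9 mL/min/kg, which is a limit of the assay and not a number.

Among the measured compounds shown here, with a single number and a single limit, compound 2 cannot be ranked, and no step between measured compounds is available as a guide.

The next compound is compound 3 `C[C@H](NC(=O)Cn1nnc2ccccc2c1=O)c1ccc(F)cc1`, which carries 4-fluorophenyl in place of 3-methylphenyl on a saturated chain carbon bound to an amide-type nitrogen and a saturated chain carbon.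

For the measured compounds named here, with no measured step to draw on, the reading of compound 2 at 11 mL/min/kg serves as the anchor in this assay. No change beyond the scatter is expected, and no direction is favoured.

The expected step is a 1.0-fold lower number from compound 2 to compound 3 (0.02 log units; within the scatter).

The estimate for compound 3 is 10.5 mL/min/kg, with an expected range of 5.5 mL/min/kg to 20 mL/min/kg.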

Compound 3, clearance: 31 mL/min/kg
For compound 3 the middle estimate is 3.0-fold (0.47 log units) below the measured one, outside the stated range (above it).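

In this assay, among these compounds, 4-fluorophenyl in place of 3-methylphenyl on a saturated chain carbon bound to an amide-type nitrogen and a saturated chain carbon gives a 2.8-fold higher number from compound 2 to compound 3 (0.45 log units; beyond the scatter) and is the first readable step. It shows that this position is not indifferent: the two groups match in heavy-atom count and in having no hydrogen-bond donors or acceptors, yet the exchange moves clearance beyond the scatter. The step is modest and rests on one pair of compounds, and nothing measured here gives a cause for it.

This single step cannot separate the loss of the methyl from the arrival of the fluorine. From the compounds shown here alone, how an unsubstituted phenyl or a pyridine ring would read at this position remains open.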